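This account rests on a few compounds, and the source may have more. Where it says the series, first, only, none or still open, it means among the compounds named here.

Three compounds from this series carry a shared core joined through an amide to a substituted aromatic ring, and they were compared in a toxicity assay on HepG2 cells (Homo sapiens) for inhibition, read by CellTiter-Glo, with a stated time of 48 h; on this read-out lower numbers stand for stronger inhibition and higher numbers for weaker inhibition. Compound 1 `COc1ccc2nc(C)cc(OCC(=O)Nc3cc(C)c(OC)c(C)c3)c2c1` gives 7940 nM in this assay. Compound 3 `COc1ccc2nc(C)cc(OCC(=O)Nc3ccc(Cl)c(C(F)(F)F)c3)c2c1` gives 79400 nM in this assay. Compound 2 `COc1ccc2nc(C)cc(OCC(=O)Nc3cc(C)c(F)c(C)c3)c2c1` reaches only a limit of the assay in this assay, > 100000 nM, so no exact number is known for it. Among the measured compounds shown here, the one change tracked between measured compounds, fluoro in place of methoxy on an aromatic carbon, gives an at least 12-fold higher number from compound 1 to compound 2 (1.10 log units; beyond the scatter); this is one of the values that sit at the limit of > 100000 nM in this assay, at which 1 of the 3 values shown sits.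

Compound 4 `COc1ccc2nc(C)cc(OCC(=O)Nc3cc(C)nc(C)n3)c2c1` replaces the whole aromatic ring: 2,6-dimethylpyrimidin-4-yl in place of 4-fluoro-3,5-dimethylphenyl on an amide-type nitrogen. For the measured compounds named here, none of the measured steps exchanges one ring for another, so no measured step bears directly on this change, and the starting point is itself only a limit. The expected step is therefore uncertain: an at least 1.2-fold lower number from compound 2 to compound 4 (0.09 log units; that floor lies within the scatter) is estimated, with the outcome in this assay possibly again a limit. Compound 4 is expected to give about 80000 nM in this assay, within a range from 15000 nM to 300000 nM.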

Compound 4, half-maximal inhibitory concentration: > 100000 nM
Compound 4 gave a limit, no number; the forecaster's own chance of this, stated with the estimate: 50%; middle value at least 1.2-fold (0.09 log units) away from the limit.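

Among the compounds shown here, compound 4, like compound 2, ends at a limit of the assay, so no step between these two compounds can be read: (the limit of > 100000 nM in this assay, at which 2 of the 4 values shown sit). In this assay the compounds shown leave open how the 2,6-dimethylpyrimidin-4-yl and 4-fluoro-3,5-dimethylphenyl groups compare, with no exact number for either compound.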